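This account rests on a few compounds, and the source may have more. Where it says the series, first, only, none or still open, it means among the compounds named here.

The series shares one core carrying a substituted phenyl on the lactam nitrogen. Compound 1 `Cc1[nH]cnc1CN1CCN(c2cccc(Cl)c2)C1=O` gives 12 nM in a functional assay (Cavia porcellus) for antagonist activity at Serotonin 3 (5-HT3) receptor (Homo sapiens); on this read-out higher numbers stand for weaker inhibition and lower numbers for stronger inhibition. Compound 2 `Cc1[nH]cnc1CN1CCN(c2cc(Cl)cc(Cl)c2)C1=O` gives 5.62 nM, a step of a 2.1-fold lower number from compound 1 to compound 2 (0.33 log units; beyond the scatter). Compound 3 `Cc1[nH]cnc1CN1CCN(c2cccc(C#N)c2)C1=O` gives 134 nM and so stands at the highest number of the three, with compound 1 the nearest and compound 2 the furthest from it; the step of an 11-fold higher number from compound 1 to compound 3 (1.05 log units; beyond the scatter) is the larger of the two measured steps.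

Compound 4 `Cc1[nH]cnc1CN1CCN(c2cccc(C(F)(F)F)c2)C1=O` differs from compound 3 by trifluoromethyl in place of cyano on an aromatic carbon. Among the measured compounds shown here, the only measured step that bears on this position directly is an 11-fold higher number from compound 1 to compound 3 (1.05 log units; beyond the scatter), which shows that exchanging chloro for cyano at this carbon moved the number a long way upward. The step of a 2.1-fold lower number from compound 1 to compound 2 (0.33 log units; beyond the scatter) concerns a second substituent and is only indirectly informative. The trifluoromethyl that enters, like the chloro of compound 1, brings no hydrogen-bond acceptor by the count above, whereas the cyano that leaves carried one. Compound 4 is therefore expected to fall back toward the number of compound 1, a step of about a 6.7-fold lower number from compound 3 to compound 4 (0.83 log units; beyond the scatter), with the uncertainty lying mostly on the side of the cyano number. Compound 4 is estimated at 20 nM, within a range of 7 nM to 60 nM.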

Compound 4, antagonist equilibrium constant: 68.5 nM
Beside the measured number, compound 4's estimate is 3.4-fold (0.53 log units) below it, outside the stated range (above it).
By their numbers in this assay, from the lowest: compound 2; then compound 1; then compounds 4 and 3 (each within the scatter of the next).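

In this assay, trifluoromethyl and cyano on this aromatic carbon cannot be told apart (a 2.0-fold lower number from compound 3 to compound 4 (0.29 log units; within the scatter)), so removing the hydrogen-bond acceptor counted on cyano does not bring the number back toward that of the chloro compound. Chloro stays apart from trifluoromethyl (a 5.7-fold higher number from compound 1 to compound 4 (0.76 log units; beyond the scatter)), which places chloro alone at the low end among the three groups compared here, with compounds 3 and 4 together at the high end; the acceptor count does not sort these three compounds, as compound 4 shares its count with compound 1 but its number with compound 3. Nothing available on these compounds gives a cause for either step.

Still open, going by these compounds, is whether the lower number belongs to chloro alone or is shared by other groups on this carbon, such as bromo, methyl or methoxy. Also open, on these data alone, is whether the second chloro of compound 2 would lower the number in the same way when it is paired with trifluoromethyl or cyano instead of chloro.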